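Swapping an ether chain for an aryl group

This account rests on a few compounds, and the source may have more. Where it says the series, first, only, none or still open, it means among the compounds named here.

compound 1 `CCN(CC)c1cc2[nH]c(C3CCCCC3)nc2cc1NC(=O)OCCOCCOC`: > 100 ug/mL
compound 2 `Cc1ccc(C(=O)Nc2cc3nc(C4CCCCC4)[nH]c3cc2N2CCCC2)cc1`: > 100 ug/mL
compound 3 `CCCN(CCC)c1cc2[nH]c(C3CCCCC3)nc2cc1NC(=O)OCc1ccccc1`: > 100 ug/mL

These three results come from an ADME assay on Vero cells (Chlorocebus sabaeus) for cytotoxicity, read by resazurin assay, with a stated time of 3 days (on this read-out lower numbers stand for stronger inhibition and higher numbers for weaker inhibition), and each is a limit of the assay rather than a number. Compound 1 stands at the limit of > 100 ug/mL in this assay, at which 3 of the 3 values shown sit. For the measured compounds named here, on these figures nothing separates compound 1 from compound 2 or compound 3, and no step between measured compounds can be read off. The unmeasured compound 4 `CCN(CC)c1cc2[nH]c(C3CCCCC3)nc2cc1NC(=O)c1ccc(OC(F)F)cc1` keeps the core of compound 1 and differs in one place: 4-(difluoromethoxy)phenyl in place of 2-(2-methoxyethoxy)ethoxy on a carbonyl carbon. Going by the values given here, with no measured step to lean on, the step of a number no higher from compound 1 to compound 4 (the limit leaves the size open) is expected to be none beyond the scatter, and the result will most likely again be reported only as a limit. Compound 4 is therefore estimated at 100 ug/mL in this assay, within a range from 40 ug/mL to 250 ug/mL.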

Compound 4, half-maximal inhibitory concentration: > 100 ug/mL
Compound 4 gave a limit, no number (the forecaster's own chance of this, stated with the estimate: 75%); the middle value lies on the limit itself.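

No step from compound 1 to compound 4 can be read in this assay, since each result is only a limit: the limit of > 100 ug/mL in this assay, at which 4 of the 4 values shown sit.

The compounds shown leave open whether 4-(difluoromethoxy)phenyl and 2-(2-methoxyethoxy)ethoxy differ at all in their effect on these cells.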